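Swapping dipropylamino for (4-methylphenyl)amino

This account rests on a few compounds, and the source may have more. Where it says the series, first, only, none or still open, it means among the compounds named here.

Measured so far in a functional assay on HeLa cells (Homo sapiens) for inhibition, read by sulforhodamine B assay; on this read-out higher numbers stand for weaker inhibition and lower numbers for stronger inhibition (limits marked)
Compound 1 `O=C1C=C(N2CCC2)C(=O)c2c1nc1n2[C@H]2OC[C@@H](O)[C@H]2OC1` gives > 16000 nM (a limit)
Compound 2 `COc1ccccc1NC1=CC(=O)c2nc3n(c2C1=O)[C@H]1OC[C@@H](O)[C@H]1OC3` gives 2950 nM
Compound 3 `CCCN(CCC)C1=CC(=O)c2nc3n(c2C1=O)[C@H]1OC[C@@H](O)[C@H]1OC3` gives > 16000 nM (a limit)

Going by these compounds, compound 3 shows only a limit in this assay and no true number, so its exact place on the scale is unknown. Compound 4 `Cc1ccc(NC2=CC(=O)c3nc4n(c3C2=O)[C@H]2OC[C@@H](O)[C@H]2OC4)cc1` has not yet been measured. It carries (4-methylphenyl)amino in place of dipropylamino on a double-bonded ring carbon and the rest of the molecule is unchanged.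

Going by the values given here, two measured steps bear on this change. The closest is an at least 5.4-fold higher number from compound 2 to compound 3 (0.73 log units; beyond the scatter) when dipropylamino replaces (2-methoxyphenyl)amino, which is the reverse kind of swap. The other is an at least 5.4-fold lower number from compound 1 to compound 2 (0.73 log units; beyond the scatter) when (2-methoxyphenyl)amino replaces azetidin-1-yl. Both are minimum sizes and both lie beyond the scatter. Among these three compounds, only compound 2 gives a true number, and it is also the only one with an aromatic ring in this group. Compound 4 has such a ring too, though with a different group on it.

Resting on compound 2 at 2950 nM as the nearest guide, a similar result is expected here. The expected step is an at least 5.3-fold lower number from compound 3 to compound 4 (0.72 log units; beyond the scatter) and it means a lower number, so stronger inhibition. The estimated value for compound 4 is 3000 nM with an expected range from 800 nM to 12000 nM in this assay.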

Compound 4, half-maximal inhibitory concentration: 3860 nM
For compound 4 the middle estimate is 1.3-fold (0.11 log units) below the measured one, within the range that was stated.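

In this assay, (4-methylphenyl)amino on the double-bonded ring carbon gives an at least 4.1-fold lower number from compound 3 to compound 4 (0.61 log units; beyond the scatter) and an at least 4.1-fold lower number from compound 1 to compound 4 (0.61 log units; beyond the scatter), so the lower number seen earlier with compound 2 is no longer tied to a single aromatic group. Set against each other, the two compounds with an aromatic ring on the amine nitrogen show a 1.3-fold higher number from compound 2 to compound 4 (0.12 log units; within the scatter), which means that 4-methylphenyl in place of 2-methoxyphenyl makes no readable difference on this read-out. The two steps from the compounds without that ring are minimum sizes only, since compound 1 and compound 3 each reach a limit rather than a true number: the limit of > 16000 nM in this assay, at which 2 of the 4 values shown sit.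

Compound 2 and compound 4 each bring an aromatic ring and an amine hydrogen together, so the compounds shown cannot tell which of these two features goes with the lower numbers. Cyclohexylamino, which has the amine hydrogen but no aromatic ring, and methyl(phenyl)amino, which has the aromatic ring but no amine hydrogen, would pull the two features apart at this position.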